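This account rests on a few compounds, and the source may have more. Where it says the series, first, only, none or still open, it means among the compounds named here.

Compound 1, `O=C(/C=C/c1ccc2c(c1)B(O)OC2)c1ccccc1`: in a toxicity assay on MCF-10A cells (Homo sapiens) for cytotoxicity, read by MTT assay, with a stated time of 48 h (on this read-out higher numbers stand for weaker inhibition and lower numbers for stronger inhibition), compound 1 gives 15900 nM.
Compound 2, `O=C(/C=C/c1ccc2c(c1)B(O)OC2)c1ccc(I)cc1`: in this assay compound 2 gives only a limit of the assay, > 100000 nM.

Compound 2 therefore stands at the limit of > 100000 nM in this assay, at which 1 of the 2 values shown sits, so its true value is not known, only that it is no lower than that limit. Among the measured compounds shown here, the one measured step that touches it is the change from hydrogen to iodo, an at least 6.2-fold higher number from compound 1 to compound 2 (0.79 log units; beyond the scatter), which is itself only a limit-bounded step.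

Compound 3, `O=C(/C=C/c1ccc2c(c1)B(O)OC2)c1ccc(OCc2ccccc2)cc1`, differs from compound 2 by benzyloxy in place of iodo on an aromatic carbon. The measured step bears on this change only in that the iodo which it introduced now leaves again; nothing measured tells what benzyloxy does on that position. The data give no ground to expect compound 3 to fall back to the number of compound 1, and the step from compound 2 to compound 3 is expected to be about a number no higher from compound 2 to compound 3 (the limit leaves the size open), that is none beyond the scatter. Compound 3 is thus estimated in this assay at 100000 nM, within 30000 nM to 300000 nM, with a real chance that the assay again reports only a limit.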

Compound 3, half-maximal inhibitory concentration: 23300 nM
The estimate for compound 3 lay 4.3-fold (0.63 log units) above the measured number; measured number below the stated range.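

Among the compounds shown here, on this aromatic carbon, the earlier compounds showed only that iodo in place of hydrogen goes with a higher number in this assay. Benzyloxy in place of iodo gives an at least 4.2-fold lower number from compound 2 to compound 3 (0.63 log units; beyond the scatter), so a substituent at this place, para to a large group, does not of itself carry the number up to a limit of the assay, and the shift seen with iodo does not hold for every group put there. Set against the unsubstituted compound, benzyloxy gives a 1.5-fold higher number from compound 1 to compound 3 (0.17 log units; within the scatter), which leaves the two indistinguishable, while the exact size of the step from iodo stays open because compound 2 holds only a limit: the limit of > 100000 nM in this assay, at which 1 of the 3 values shown sits.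

The compounds shown leave open whether the high number belongs to iodo alone or is shared by other halogens such as bromo or chloro, and whether a small methoxy on the same carbon reads like benzyloxy. They also leave open how an amine or a carboxylic acid at this place would read in this assay, and whether a longer chain ending in the same aromatic ring would keep the number of benzyloxy.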